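The compounds below may be only part of what the source reports. "The series", "measured", "known", "first", "only" and "open" are said of these compounds alone.

Two compounds built on a shared core have been examined in an assay on isolated protein for inhibition of phosphatidylinositol 4,5-bisphosphate 3-kinase catalytic subunit beta isoform (Homo sapiens), read by 33P incorporation, with a stated time of 60 min; on this read-out lower numbers stand for stronger inhibition and higher numbers for weaker inhibition. Compound 1 `Cc1ccc2c(/C=N/N(C)S(=O)(=O)c3cc([N+](=O)[O-])ccc3C)cnn2c1` gives only a limit of the assay, > 1000 nM, and no number is known for it. Among the measured compounds shown here, compound 2 `C/C(=N\N(C)S(=O)(=O)c1cc([N+](=O)[O-])ccc1C)c1cnn2ccc(C#N)cc12` gives 600 nM in this assay, and this is the only number in the set. The other value, that of compound 1, is a limit (the limit of > 1000 nM in this assay, at which 1 of the 2 values shown sits). Compound 3 `CC/C(=N\N(C)S(=O)(=O)c1cc([N+](=O)[O-])ccc1C)c1cnn2ccc(C#N)cc12` differs from compound 2 by methyl in place of hydrogen on a saturated chain carbon bound to a carbon with a double bond to nitrogen. For the measured compounds named here, no pair of measured compounds separated by a single change exists here, so there is no measured step to lean on. The change is expected to shift potency little, and the step of a 1.2-fold higher number from compound 2 to compound 3 (0.07 log units; within the scatter) is the estimate, a move no larger than the usual scatter. Compound 3 is estimated at 700 nM, within 250 nM to 2000 nM in this assay.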

Compound 3, half-maximal inhibitory concentration: > 1000 nM
Compound 3: no number, only a limit; the forecaster's own chance of this, stated with the estimate: 25%; middle value at least 1.4-fold (0.15 log units) away from the limit.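

In this assay, among the compounds shown here, this is the first measured step at this position: methyl in place of hydrogen on a saturated chain carbon bound to a carbon with a double bond to nitrogen, which turns methyl into ethyl, reads an at least 1.6-fold higher number from compound 2 to compound 3 (0.22 log units; that floor lies within the scatter). Compound 3 gives > 1000 nM, which is a limit of the assay and not a number. The ethyl compound therefore shows no gain in potency, but the size of the step stays unresolved, and the set now rests largely on a single ceiling: the limit of > 1000 nM in this assay, at which 2 of the 3 values shown sit.

Going by these compounds, what a true number for compound 3 would be remains open. So does whether a longer chain such as propyl, a cyclopropyl ring or an amine on this saturated chain carbon would give a value that can be read in this assay.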